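Tert-Butyl for 4-Fluorophenyl in a Vero Cell Cytotoxicity Series

The source may hold more compounds than are shown below. What is called first, only, known or untested is meant among the compounds shown, and "the series" means these compounds.

Measured so far:
Compound 1 `O=C(O)c1cn(-c2ccc(F)cc2)c2nc(N3CCN(C(c4ccccc4)c4ccc(Cl)cc4)CC3)c([N+](=O)[O-])cc2c1=O` — in an ADME assay on Vero cells (Chlorocebus sabaeus) for cytotoxicity, read by MTT assay, with a stated time of 72 h (on this read-out lower numbers stand for stronger inhibition and higher numbers for weaker inhibition), compound 1 gives 102000 nM.
Compound 2 `O=C(O)c1cn(-c2ccc(F)cc2)c2nc(N3CCC(N4CCCCC4)CC3)c([N+](=O)[O-])cc2c1=O` — in this assay compound 2 gives > 126000 nM, which is a limit of the assay and not a number.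
Compound 3 `CC(C)(C)n1cc(C(=O)O)c(=O)c2cc([N+](=O)[O-])c(N3CCN(C(c4ccccc4)c4ccc(Cl)cc4)CC3)nc21` — in this assay compound 3 gives > 108000 nM, which is again a limit and not a number.

Compound 1 and compound 3 share a core and differ in one place: tert-butyl in place of 4-fluorophenyl on an aromatic nitrogen. This change gives an at least 1.0-fold higher number from compound 1 to compound 3 (0.02 log units; that floor lies within the scatter). The step is only a floor because compound 3 sits at the limit of > 108000 nM in this assay, at which 1 of the 3 values shown sits, so how much further the number might move is not known. Compound 2 carries a different side group on the shared core; the difference between the two cores is not broken down here.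

Compound 4 `CC(C)(C)n1cc(C(=O)O)c(=O)c2cc([N+](=O)[O-])c(N3CCC(N4CCCCC4)CC3)nc21` has not yet been measured in this assay. It differs from compound 2 by tert-butyl in place of 4-fluorophenyl on an aromatic nitrogen, the same change made from compound 1 to compound 3, at the same place in the molecule. Compound 2 already sits at the limit of > 126000 nM in this assay, at which 1 of the 3 values shown sits, and the earlier step was a floor within the scatter, so compound 4 is expected to move by a step that the limit leaves unreadable from compound 2 to compound 4, again most likely ending at a limit rather than a number. The estimate for compound 4 in this assay is 135000 nM, expected to fall between 90000 nM and 220000 nM.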

Compound 4, half-maximal inhibitory concentration: > 136000 nM
Compound 4 was reported as a limit; the forecaster's own chance of this, stated with the estimate: 80%; at least 1.0-fold (0.00 log units) between middle value and limit.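

In this assay compound 4 gives > 136000 nM, which is a limit of the assay and not a number. Compound 2 also stands at a limit, and no step can be read between compound 2 and compound 4. The compounds shown leave open what the true numbers behind these limits are, and whether tert-butyl in place of 4-fluorophenyl changes the number at all.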